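The source may hold more compounds than are shown below. What is called first, only, known or untested is meant among the compounds shown, and "the series" means these compounds.

Measured compounds:
compound 1 `COc1cc(N(Cc2ccccc2)S(=O)(=O)c2ccc(C)cc2)cc(OC)c1OC` — in a functional assay on MCF7 cells (Homo sapiens) for inhibition, read by MTT assay, with a stated time of 48 h (on this read-out lower numbers stand for stronger inhibition and higher numbers for weaker inhibition), compound 1 gives 10200 nM;
compound 2 `COc1cc(N(Cc2nc3ccccc3[nH]2)S(=O)(=O)c2ccc(Br)cc2)cc(OC)c1OC` — in this assay compound 2 gives 7740 nM;
compound 3 `COc1cc(N(Cc2nc3ccccc3[nH]2)S(=O)(=O)c2ccc(C(C)(C)C)cc2)cc(OC)c1OC` — in this assay compound 3 gives 33600 nM.

Compound 2 has the lowest of the three numbers, but compound 1 sits within the scatter of it, so the two cannot be ranked; only compound 3 lies clearly apart, as the step of a 4.3-fold higher number from compound 2 to compound 3 (0.64 log units; beyond the scatter) shows. The unmeasured compound 4 `COc1cc(N(Cc2nc3ccccc3[nH]2)C(=O)c2cccc(Cl)c2)cc(OC)c1OC` differs from compound 2 in one place: (3-chlorophenyl)carbonyl in place of (4-bromophenyl)sulfonyl on a nitrogen on an aromatic ring. Among the compounds with values here, no measured step touches this change; the single step known, from compound 2 to compound 3, swaps one substituent on an aromatic carbon and leaves the sulfonyl in place, so it gives no guide to exchanging the whole (4-bromophenyl)sulfonyl for a (3-chlorophenyl)carbonyl. With nothing to lean on, compound 4 is expected to land near compound 2, with a wide range and no step beyond the scatter asserted: a 1.3-fold higher number from compound 2 to compound 4 (0.11 log units; within the scatter). The estimate for compound 4 in this assay is 10000 nM, between 3000 nM and 40000 nM.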

Compound 4, half-maximal inhibitory concentration: 34900 nM
Estimate against measurement, compound 4: 3.5-fold (0.54 log units) below; low and high end bracket the measured number.
By their numbers in this assay, from the lowest: compounds 2 and 1 (each within the scatter of the next); then compounds 3 and 4 (each within the scatter of the next).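

In this assay, exchanging the whole group on this nitrogen changes the number beyond the scatter: a 4.5-fold higher number from compound 2 to compound 4 (0.65 log units; beyond the scatter). The result therefore shows that this group matters as well as the substituent on an aromatic carbon altered in the earlier step, although the exchange replaces sulfonyl with carbonyl and also alters the halogen and its numbered ring position, so the step belongs to the whole exchange and to no single part of it. Nothing among the data given accounts for this step.

The compounds shown leave open how much of the step follows the carbonyl itself, which a (4-bromophenyl)carbonyl or a (3-chlorophenyl)sulfonyl group would help to separate. They also leave open how an amine or a carboxylic acid on that aromatic ring would read.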